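A few compounds are considered here, and "the series" means these few. Any claim that something is new, unique, unknown or untested is made for them only; others in the source may bear on it.

Measured compounds:
compound 1, `COc1ccc(C2Oc3ccccc3N(CCCCCN3C(C)CCCC3C)C2=O)cc1`: 2.3%
compound 2, `COc1ccc(C2Oc3ccccc3N(CCCCCN3C(C)CCCC3C)C2=O)cc1OC`: 0%

Both numbers come from an assay on isolated protein for inhibition of serine protease 1 (Homo sapiens), tested at 100 uM; on this read-out higher numbers stand for more inhibition at the one concentration tested (going by the name of the read-out) and lower numbers for less inhibition. Compound 2 stands at the lowest of the two values, and its nearest neighbour is compound 1, whose step a number 2.3 percentage points lower from compound 1 to compound 2 (within the scatter) lies within the scatter; the two compounds therefore cannot be told apart on this assay.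

Compound 3, `CC1CCCC(C)N1CCCCCN1C(=O)C(c2ccc(C(=N)NO)cc2)Oc2ccccc21`, has not yet been measured in this assay. It differs from compound 2 as follows: a group of 10 heavy atoms (7 carbon, 2 nitrogen, 1 oxygen; one six-membered aromatic ring of carbon only) in place of a group of 10 heavy atoms (8 carbon, 2 oxygen; one six-membered aromatic ring of carbon only), on a saturated ring carbon. Within the data shown here, the only measured step, from compound 1 to compound 2, concerns a methoxy in place of hydrogen on an aromatic carbon and is within the scatter; it gives no direct guide to a change in which the whole 3,4-dimethoxyphenyl group leaves. Among the measured compounds shown here, no measured step therefore bears on this change, and the expectation rests on the low values of both measured compounds. Compound 3 is estimated at 8%, within 0% to 35%, an expected step of a number 8 percentage points higher from compound 2 to compound 3 (within the scatter) that is not clearly beyond the scatter.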

Compound 3, a percentage reported as inhibition, at one concentration (the size of the read-out at that concentration, not a potency): 8%
For compound 3 middle estimate and measured number coincide at the digits printed; the range from low to high includes it.
By their numbers in this assay, from the lowest: compounds 2, 1 and 3 (each within the scatter of the next).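

In this assay, putting the new group with its hydroxyamidine function in place of 3,4-dimethoxyphenyl on the saturated ring carbon gives a number 8 percentage points higher from compound 2 to compound 3 (within the scatter), and the same comparison read as a change on the aromatic carbon alone, where that function replaces methoxy, gives a number 5.7 percentage points higher from compound 1 to compound 3 (within the scatter). Both steps lie within the scatter, so a group with 3 hydrogen-bond donors at this position, where 3,4-dimethoxyphenyl has 0, leaves all three compounds indistinguishable on this read-out. Nothing available explains this result.

On these data alone, whether an unsubstituted amidine, a primary amine or a carboxylic acid on that aromatic ring would give a step beyond the scatter stays open. So does whether a longer chain on the ring nitrogen would change the read-out for any of these compounds.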